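A few compounds are considered here, and "the series" means these few. Any claim that something is new, unique, unknown or untested is made for them only; others in the source may bear on it.

The shared core is carried by compound 1 `COc1ccccc1-c1ncnn1-c1cc(OC)c(OC)c(OC)c1` together with two further measured compounds, compound 2 `COc1cc(-c2ncnn2-c2ccccc2)cc(OC)c1OC` and compound 3 `COc1cc(-c2ncnn2-c2ccc(Cl)cc2Cl)cc(OC)c1OC`. In a functional assay on MCF7 cells (Homo sapiens) for antiproliferative activity, read by MTT assay, with a stated time of 72 h (on this read-out lower numbers stand for stronger inhibition and higher numbers for weaker inhibition), compound 1 gives > 10000 nM, which is a limit of the assay rather than a number. Compound 2 likewise gives > 10000 nM, again a limit. Compound 3 gives > 10000 nM, also a limit. Compound 1 therefore stands where all of the values shown stand, at the limit (the limit of > 10000 nM in this assay, at which 3 of the 3 values shown sit), and nothing sets it apart from the other two. Among the measured compounds shown here, the only step between measured compounds that differ in one place, a step that the two limits leave unreadable from compound 2 to compound 3, is left unreadable by the two limits and concerns a different position of the core.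

The unmeasured compound 4 `COc1cc(-n2ncnc2-c2cccc(F)c2)cc(OC)c1OC` differs from compound 1 in one place: 3-fluorophenyl in place of 2-methoxyphenyl on an aromatic carbon. For the measured compounds named here, no measured step touches this change, and with every value shown sitting at the limit of > 10000 nM in this assay, at which 3 of the 3 values shown sit, no direction or size can be drawn from the data for it. Compound 4 is accordingly expected to stay near the limit, so the expected step that the limit leaves unreadable from compound 1 to compound 4 amounts to none beyond the scatter. The estimate for compound 4 in this assay is 15000 nM, with a range from 4000 nM to 60000 nM.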

Compound 4, half-maximal inhibitory concentration: > 10000 nM
Compound 4: a limit, no number; the forecaster's own chance of this, stated with the estimate: 80%; the middle value lies beyond the limit too.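

In this assay compound 4 gives > 10000 nM as a limit of the assay and not a number. Among the compounds shown here, no step from compound 1 to compound 4 can be read, since both sit at the same limit: the limit of > 10000 nM in this assay, at which 4 of the 4 values shown sit.

The compounds shown leave open whether any change to the shared core brings a measurable value in this assay at all.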